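From Piperidine to Aminopyridine: One Expected Step

The source may report more compounds than this note shows. Statements on the series, on what has been measured and on what is new or still open speak of the compounds shown alone.

Measured so far:
compound 1, `Oc1c(C(c2ccc(F)cc2)N2CCCCC2)ccc2cccnc12`: 690 nM
compound 2, `CC(=O)c1cc2ccc(C(c3ccc(F)cc3)N3CCCCC3)c(O)c2o1`: 1230 nM

Of the compounds shown here, two have been measured in an assay for inhibition of protein disulfide-isomerase (Homo sapiens), with a stated time of 1 h; on this read-out lower numbers stand for stronger inhibition and higher numbers for weaker inhibition. Compound 1 gives 690 nM, and compound 2 gives 1230 nM. Compound 1 has the lowest of the two numbers, but the number of compound 2 lies within the scatter of repeated measurements, so the two cannot be told apart on this read-out. Going by the values given here, no pair of measured compounds differs in a single place, so no measured step is available to guide what follows.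

Compound 3 `Cc1ccnc(NC(c2ccc(F)cc2)c2ccc3cccnc3c2O)c1` differs from compound 1 in one place: (4-methylpyridin-2-yl)amino in place of piperidin-1-yl on a saturated chain carbon bound to two aromatic carbons. Nothing measured shows how such a change bears on the read-out, so any expectation rests on the shared core of compound 1 alone. For compound 3 the estimate is a small step toward a higher number, a 1.6-fold higher number from compound 1 to compound 3 (0.20 log units; within the scatter), which may well fall within the scatter. Compound 3 is expected to give 1100 nM in this assay, with a range from 350 nM to 3500 nM.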

Compound 3, half-maximal inhibitory concentration: 140 nM
Estimate against measurement, compound 3: 7.9-fold (0.90 log units) above; measured number outside the range, below it.
By their numbers in this assay, from the lowest: compound 3; then compounds 1 and 2 (each within the scatter of the next).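

Placing (4-methylpyridin-2-yl)amino in place of piperidin-1-yl on a saturated chain carbon bound to two aromatic carbons gives, in this assay, a 4.9-fold lower number from compound 1 to compound 3 (0.69 log units; beyond the scatter) as the first readable step in this series. It shows that the read-out responds to the group at this position, and that a six-membered aromatic ring on an amino link, with its hydrogen-bond donor, is accepted there in place of a six-membered non-aromatic ring and goes with a lower number. No available measurement explains this step.

The compounds shown leave open which part of the entering group goes with the lower number, as the aromatic ring, the amino hydrogen and the methyl group all enter together in this single change. From the compounds shown here alone, an unsubstituted pyridin-2-ylamino group or a phenylamino group at the same place would begin to separate these parts, and whether the same exchange carries over to the core of compound 2 also remains open.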